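The compounds below may be only part of what the source reports. "The series", "measured", "known", "first", "only" and "open" are said of these compounds alone.

Working notes on the series. Compound 2 `CS(=O)(=O)c1cnc(O[C@H]2CC[C@H](OC3CCN(C(=O)Oc4ccccc4)CC3)CC2)cn1` stands lowest of the two numbers measured in a functional assay on isolated protein for agonist activity at Glucose-dependent insulinotropic receptor (Rattus norvegicus), read by HTRF and cAMP accumulation; a lower number here means a smaller maximal response, a higher number a larger maximal response: compound 2 gives 104%, while compound 1 `C[C@H](CF)OC(=O)N1CCC(O[C@H]2CC[C@H](Oc3cnc(S(C)(=O)=O)cn3)CC2)CC1` gives 115%. For the measured compounds named here, the one step recorded between them, a number 11 percentage points lower from compound 1 to compound 2 (beyond the scatter), is the only measured change at the carbamate end of the shared core. Compound 3 `CS(=O)(=O)c1cnc(O[C@H]2CC[C@H](OC3CCN(C(=O)C4(C(F)(F)F)CCCC4)CC3)CC2)cn1` differs from compound 2 at that end as follows: a group of 9 heavy atoms (6 carbon, 3 fluorine; one five-membered non-aromatic ring of carbon only) in place of a group of 7 heavy atoms (6 carbon, 1 oxygen; one six-membered aromatic ring of carbon only), on a carbonyl carbon. Going by the values given here, no measured pair covers this change, since the step from compound 1 to compound 2 keeps the oxygen on the carbonyl carbon, whereas here it leaves and a ring of carbon only enters. That earlier step was modest, so a step of similar size or none beyond the scatter is expected here, with no firm direction. The estimate for compound 3 in this assay is 105%, with a range from 85% to 125%, corresponding to an expected step of a number 1 percentage points higher from compound 2 to compound 3 (within the scatter).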

Compound 3, largest response reached (Emax), in percent of the reference or control that the assay uses: 124%
Compound 3: the middle estimate sits 19 percentage points below what was measured, and the stated range covers the measured number.
By their numbers in this assay, from the lowest: compound 2; then compounds 1 and 3 (each within the scatter of the next).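

In this assay, the oxygen on the carbonyl carbon is not required for a full response in these compounds: replacing the phenoxy group with a group built on a five-membered non-aromatic ring of carbon only gives a clear gain (a number 20 percentage points higher from compound 2 to compound 3 (beyond the scatter)). Set against the 1-(fluoromethyl)ethyl group, the same ring-bearing group gives no difference beyond the scatter (a number 9 percentage points higher from compound 1 to compound 3 (within the scatter)), so the phenyl carbamate remains the one low point among the three. Nothing on hand explains either step.

The ring and the fluorine atoms enter together, leaving their separate contributions unresolved; an unfluorinated five-membered ring of carbon only on the carbonyl carbon would separate them. From the compounds shown here alone, how an amine at this place would read also remains open.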